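The compounds below may be only part of what the source reports. "The series", "measured", "known", "first", "only" and "open" are said of these compounds alone.

In an ADME assay on a cell-free system (plasma, Homo sapiens) for protein binding, with Plasma (Rattus norvegicus) as the target, compound 1 `O=C(O)c1cn(Cc2ccc(-n3cccn3)cc2)c2cccc(F)c2c1=O` gives 89.8% and compound 2 `Cc1cn(-c2ccc(Cn3cc(C(=O)O)c(=O)c4c(F)cccc43)cc2)cn1` gives 89.8%. Compound 2 therefore stands level with compound 1, and these two values are all that has been measured so far. Compound 3 `O=C(O)c1cn(Cc2ccc(-n3ccc4ncccc43)cc2)c2cccc(F)c2c1=O` keeps the shared core and alters only the group on an aromatic carbon, para to a large group: a group of 9 heavy atoms (7 carbon, 2 nitrogen; one five-membered aromatic ring with 1 hetero atom, one six-membered aromatic ring with 1 hetero atom) in place of a group of 6 heavy atoms (4 carbon, 2 nitrogen; one five-membered aromatic ring with 2 hetero atoms), on an aromatic carbon. For the measured compounds named here, one measured step bears on this change: no change at the digits printed from compound 1 to compound 2 (within the scatter), with 4-methyl-1H-imidazol-1-yl in place of 1H-pyrazol-1-yl. Going by the values given here, that step exchanged one single five-membered aromatic ring for another, whereas the entering group here has two aromatic rings, and no measured step covers such a change. The guide is therefore weak, and only a modest rise is expected, with an estimated size of a 1.3-fold lower unbound fraction from compound 2 to compound 3 (0.11 log units; within the scatter). The expected value for compound 3 is 92%, within a range from 85% to 97%.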

Compound 3, plasma protein binding: 96.1%
For compound 3 the middle estimate is 2.1-fold (0.31 log units) (unbound fraction) above the measured one; low and high end bracket the measured number.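

In this assay, this position looked indifferent while one five-membered aromatic ring replaced another, giving no change at the digits printed from compound 1 to compound 2 (within the scatter). The group that brings a second aromatic ring, a six-membered one alongside the five-membered one, does register, with a 2.6-fold lower unbound fraction from compound 2 to compound 3 (0.42 log units; beyond the scatter), and the step from the other single-ring group is the same size, with a 2.6-fold lower unbound fraction from compound 1 to compound 3 (0.42 log units; beyond the scatter). So the position can respond to this change in the substituent, and the response appears from both single-ring starting groups.

Nothing measured here explains this shift. The compounds shown leave open whether the larger size or the second aromatic ring matters more, and how a single pyridine ring, a plain phenyl ring or an open-chain amine at this position would compare.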